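The source may hold more compounds than are shown below. What is called first, only, known or untested is meant among the compounds shown, and "the series" means these compounds.

Series notes, shared core with a phenyl group and two amino groups on the fused ring system of compound 1 `Nc1cc(N)c2nc(-c3ccccc3)c(NCc3ccc(Cl)c(Cl)c3)nc2c1`. In a functional assay on TK-10 cells (Homo sapiens) for inhibition, read by sulforhodamine B assay, with a stated time of 48 h (a higher number here means that more compound is tolerated, a lower number that less compound is tolerated), compound 1 gives 72400 nM. Compound 2 `COc1ccc(CNc2nc3cc(N)cc(N)c3nc2-c2ccccc2)cc1OC` carries a 3,4-dimethoxyphenyl in place of the 3,4-dichlorophenyl of compound 1, and in this assay compound 2 gives 64600 nM; the step of a 1.1-fold lower number from compound 1 to compound 2 (0.05 log units; within the scatter) lies within the scatter. Compound 3 `CCOC(=O)[C@H](CCC(=O)O)NC(=O)c1ccc(Sc2nc3cc(N)cc(N)c3nc2-c2ccccc2)cc1`, with a thioether link to a substituted benzamide, gives only a limit in this assay, < 100000 nM, so the limit of < 100000 nM in this assay, at which 1 of the 3 values shown sits, is where one of the three values sits. Among the two actual numbers compound 2 stands lowest, with compound 1 as its nearest neighbour, and the two cannot be ordered against each other.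

Compound 4 `COc1cc(CNc2nc3cc(N)cc(N)c3nc2-c2ccccc2)cc(OC)c1OC` differs from compound 2 by methoxy in place of hydrogen on an aromatic carbon; the new group sits ortho to a methoxy group, meta to a large group and meta to a methoxy group. Going by the values given here, the only measured step that bears on this region, from the dichloro to the dimethoxy pattern in a 1.1-fold lower number from compound 1 to compound 2 (0.05 log units; within the scatter), stayed within the scatter, and no measured pair adds a methoxy group to an already methoxylated ring. No movement beyond the scatter is therefore expected in this assay, and the step of a 1.0-fold higher number from compound 2 to compound 4 (0.00 log units; within the scatter) is the estimate. For compound 4 the expected value is 65000 nM, with a range from 30000 nM to 130000 nM.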

Compound 4, concentration lethal to 50% of the cells: < 50200 nM
Compound 4 ended at the assay's limit; the forecaster's own chance of this, stated with the estimate: 25%; middle value at least 1.2-fold (0.11 log units) from the limit.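

In this assay compound 4 returns a limit and not a number: the limit of < 50200 nM in this assay, at which 1 of the 4 values shown sits. Methoxy in place of hydrogen on this aromatic carbon, ortho to a methoxy group and meta to a methoxy group, gives an at least 1.2-fold lower number from compound 2 to compound 4 (0.10 log units; that floor lies within the scatter), so the floor of the step does not separate the two compounds, and only that floor can be read from this pair. The earlier compounds shown here showed a swap of the whole substitution pattern on this ring, whereas this pair isolates one added methoxy group, and that addition gives no change beyond the scatter that can be stated, though the full size of the step remains undetermined.

The compounds shown leave open whether a hydroxy group, an amine or a carboxylic acid on this same aromatic carbon, or a longer chain such as ethoxy in place of methoxy, would give a number clearly apart from compound 2. They also leave open how the same ring behaves with this carbon substituted but the other two methoxy groups absent, since every measured pair here changes the ring with those groups or their chloro counterparts in place.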